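Phenyl substituent swap from compound 3 to compound 4

The compounds below may be only part of what the source reports. "The series", "measured", "known", "first", "only" and "open" are said of these compounds alone.

In a functional assay on NB-4 cells (Homo sapiens) for cytotoxicity, read by CCK-8 assay, with a stated time of 24 h (a lower number here means a stronger inhibitor, a higher number a weaker inhibitor), compound 3 `C=CC(=O)N1C(=O)CC(c2cccc(Cl)c2)Sc2ccccc21` gives 31700 nM. This lies within the scatter of compound 1 `C=CC(=O)N1C(=O)CC(c2ccc(C(F)(F)F)cc2)Sc2ccccc21` at 38600 nM and of compound 2 `C=CC(=O)N1C(=O)CCSc2ccccc21` at 22400 nM, so the three values show no ranking. Compound 4 `C=CC(=O)N1C(=O)CC(c2ccc(C#N)cc2)Sc2ccccc21` carries 4-cyanophenyl in place of 3-chlorophenyl on a saturated ring carbon. Among the measured compounds shown here, only one measured step bears on this position, a 1.4-fold higher number from compound 2 to compound 3 (0.15 log units; within the scatter), and it stays within the scatter. For the measured compounds named here, no measured step compares two substituted phenyl groups directly. No change beyond the scatter is therefore expected in this assay. The expected step is a 1.0-fold higher number from compound 3 to compound 4 (0.00 log units; within the scatter). For compound 4 the estimate is 32000 nM, with an expected range of 18000 nM to 55000 nM.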

Compound 4, half-maximal inhibitory concentration: 62400 nM
The estimate for compound 4 lay 2.0-fold (0.29 log units) below the measured number; measured number above the stated range.
By their numbers in this assay, from the lowest: compounds 2, 3, 1 and 4 (each within the scatter of the next, the first and the last beyond it).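

In this assay a step beyond the scatter now appears at this saturated ring carbon: a 2.8-fold higher number from compound 2 to compound 4 (0.44 log units; beyond the scatter), a modest change for 4-cyanophenyl in place of hydrogen. Among the substituted phenyl groups, a 2.0-fold higher number from compound 3 to compound 4 (0.29 log units; within the scatter) and a 1.6-fold higher number from compound 1 to compound 4 (0.21 log units; within the scatter) both stay within the scatter, so these swaps do not separate the groups. No available evidence accounts for the step from hydrogen.

Open, from the compounds shown here alone, is whether an amine or a carboxylic acid on the phenyl ring would separate from these groups. Going by these compounds, a longer chain in place of the phenyl group also remains open.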